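A Five-Membered Ring Swap on the Sulfonyl-Bound Carbon

The compounds below may be only part of what the source reports. "The series", "measured", "known", "first", "only" and "open" are said of these compounds alone.

Three compounds were measured in a functional assay, read by Griess assay, with a stated time of 150 min, tested at 50 ug/mL; on this read-out higher numbers stand for a stronger effect at the one concentration tested and lower numbers for a weaker effect:

Compound 1, `COc1ccc(C2=NN(c3ccccc3)C(c3ccc(C)cc3)C2S(=O)(=O)CC2=NCCO2)cc1`, gives 59.1%.
Compound 2, `O=S(=O)(CC1=NCCO1)c1c(-c2ccccc2)nn(-c2ccccc2)c1-c1ccccc1`, gives 54.5%.
Compound 3, `COc1ccc(C2=NN(c3ccccc3)C(c3ccc(C)cc3)C2S(=O)(=O)CC2=NCCS2)cc1`, gives 39.4%.

Compound 1 and compound 2 lie within the usual scatter of each other, so no order between them is claimed. Compound 2 lies above compound 3 by more than the scatter, and that is all their two values show. The difference between the core of compound 1 and the core of compound 2 is not broken down here.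

One change is seen in a measured pair. From compound 1 to compound 3 the change is a group of 5 heavy atoms (3 carbon, 1 nitrogen, 1 sulfur; one five-membered non-aromatic ring with 2 hetero atoms) in place of a group of 5 heavy atoms (3 carbon, 1 nitrogen, 1 oxygen; one five-membered non-aromatic ring with 2 hetero atoms), on a saturated chain carbon bound to a sulfonyl sulfur. That change produced a number 19.7 percentage points lower from compound 1 to compound 3 (beyond the scatter).

Compound 4, `O=S(=O)(CC1=NCCS1)c1c(-c2ccccc2)nn(-c2ccccc2)c1-c1ccccc1`, has not yet been measured in this assay. Within the data shown here, it differs from compound 2 by a group of 5 heavy atoms (3 carbon, 1 nitrogen, 1 sulfur; one five-membered non-aromatic ring with 2 hetero atoms) in place of a group of 5 heavy atoms (3 carbon, 1 nitrogen, 1 oxygen; one five-membered non-aromatic ring with 2 hetero atoms), on a saturated chain carbon bound to a sulfonyl sulfur, the same change, on the same place, as the one from compound 1 to compound 3. Because that change gave a number 19.7 percentage points lower from compound 1 to compound 3 (beyond the scatter), a step of comparable size is expected here too, namely a number 18.5 percentage points lower from compound 2 to compound 4 (beyond the scatter). On that basis compound 4 is estimated to give 36%, with the expectation spanning from 22% to 50%. This rests on one measured pair only, so the uncertainty is wide.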

Compound 4, a percentage reported as activity, at one concentration (the size of the read-out at that concentration, not a potency): "not active" (no number reported)
No number was reported for compound 4; there is nothing to compare the estimate with.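

For compound 4 no number was reported in this assay, so no new step can be read from compound 2 to compound 4. The compounds shown leave open how large the effect of this ring swap is on the core of compound 2, and whether it matches the step seen on the core of compound 1. Nothing shown here bears on the reason for the result.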